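Series notes: piperidine replaced by methylsulfonyl piperazine

The source may hold more compounds than are shown below. What is called first, only, known or untested is meant among the compounds shown, and "the series" means these compounds.

Compound 2 `c1cc([C@H]2CC[C@]3(CC2)OOC2(O3)C3CC4CC(C3)CC2C4)ccc1OCCC1CCNCC1` stands lowest among the three readings in an ADME assay on microsomes from liver (Homo sapiens) for metabolic stability, read by LC-MS, tested at 1 uM; on this read-out higher numbers stand for fast clearance and lower numbers for slow clearance: its result is a limit, < 7 mL.min-1.g-1, and (the limit of < 7 mL.min-1.g-1 in this assay, at which 1 of the 3 values shown sits). Compound 1 `CC(C)(O)CN1CCC(Oc2ccc([C@H]3CC[C@]4(CC3)OOC3(O4)C4CC5CC(C4)CC3C5)cc2)CC1` gives 18 mL.min-1.g-1, and compound 3 `O=S(=O)(c1ccc([C@H]2CC[C@]3(CC2)OOC2(O3)C3CC4CC(C3)CC2C4)cc1)N1CCNCC1` gives 16 mL.min-1.g-1 in this assay. The step to compound 4 `CS(=O)(=O)N1CCN(CCCOc2ccc([C@H]3CC[C@]4(CC3)OOC3(O4)C4CC5CC(C4)CC3C5)cc2)CC1` is (4-(methylsulfonyl)piperazin-1-yl)methyl in place of piperidin-4-yl on a saturated chain carbon, two bonds along the chain from an oxygen on an aromatic ring. For the measured compounds named here, two measured steps bear on it: an at least 2.2-fold higher number from compound 2 to compound 3 (0.35 log units; beyond the scatter) and an at least 2.5-fold lower number from compound 1 to compound 2 (0.41 log units; beyond the scatter); each leaves compound 2 as the one compound with the lowest reading. Compound 4 carries the (4-(methylsulfonyl)piperazin-1-yl)methyl rather than the piperidin-4-yl, so an upward step of about an at least 2.1-fold higher number from compound 2 to compound 4 (0.33 log units; beyond the scatter) in this assay is expected. Compound 4 is therefore estimated at 15 mL.min-1.g-1, with a range from 6 mL.min-1.g-1 to 35 mL.min-1.g-1.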

Compound 4, intrinsic clearance in microsomes: 68 mL.min-1.g-1
Compound 4: middle estimate off by 4.5-fold (0.66 log units), on the low side; measured number outside the range, above it.
By their numbers in this assay, from the lowest: compounds 3 and 1 (each within the scatter of the next); then compound 4. At a limit, below all of these: compound 2.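

In this assay, this position on a saturated chain carbon, two bonds along the chain from an oxygen on an aromatic ring, responds strongly to the change: an at least 9.7-fold higher number from compound 2 to compound 4 (0.98 log units; beyond the scatter). Compound 2 stands only as a limit, < 7 mL.min-1.g-1, so the step has a lower bound and no fixed size. Clearance here therefore depends heavily on the group carried at the end of this chain.

As far as these compounds go, it remains open whether the piperazine ring or the methylsulfonyl carries the step. An unsubstituted piperazine or an acetyl piperazine on the same chain would separate the two.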